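The compounds below may be only part of what the source reports. "The series", "measured", "known", "first", "only" and "open" are said of these compounds alone.

Measured in an assay on isolated protein for inhibition of Polyunsaturated fatty acid 5-lipoxygenase (Rattus norvegicus); a lower number here means a stronger inhibitor, a higher number a weaker inhibitor:
compound 1 `CCCOCC1CN(c2ccccc2)NC1=O` — 260 nM
compound 2 `COCCOCC1CN(c2ccccc2)NC1=O` — 520 nM
compound 3 `COCCC1CN(c2ccccc2)NC1=O` — 480 nM; 10300 nM; 350 nM (3 entries)

Of the two single numbers, compound 2 carries the larger, yet a 2.0-fold higher number from compound 1 to compound 2 (0.30 log units; within the scatter). Compound 3 is known only through (the several entries of compound 3 in this assay, 480 nM; 10300 nM; 350 nM (3 entries)), which spread widely. The next compound, compound 4 `CN(C)CCC1CN(c2ccccc2)NC1=O`, carries (dimethylamino)methyl in place of 2-methoxyethoxy on a saturated chain carbon bound to a saturated ring carbon. For the measured compounds named here, no measured step exchanges an ether for an amine, so only indirect guidance exists: a 2.0-fold higher number from compound 1 to compound 2 (0.30 log units; within the scatter) shows that changing the side chain moved little, and compound 3, with a shorter side chain, sits in the same region. Compound 4 is therefore expected to give a step of a 1.0-fold lower number from compound 2 to compound 4 (0.02 log units; within the scatter), nothing beyond the scatter, though the broad entries of compound 3 widen the range. In this assay compound 4 is estimated at 500 nM, between 150 nM and 2500 nM.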

Compound 4, half-maximal inhibitory concentration: > 1000 nM
Compound 4 ended at the assay's limit; the forecaster's own chance of this, stated with the estimate: 10%; middle value at least 2.0-fold (0.30 log units) from the limit.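

In this assay compound 4 gives > 1000 nM, which is a limit of the assay and not a number. The side chain on the saturated ring carbon does respond to an amine: the exchange for propoxy gives an at least 3.8-fold higher number from compound 1 to compound 4 (0.58 log units; beyond the scatter). Against 2-methoxyethoxy the reading is less firm, with an at least 1.9-fold higher number from compound 2 to compound 4 (0.28 log units; that floor lies within the scatter), so only the comparison with the propoxy chain is secure.

On these data alone, how far compound 4 lies past its limit remains open, as does the effect of a primary amine or a carboxylic acid on this chain. Compound 3 offers no firm reference point for the shorter chain: the several entries of compound 3 in this assay, 480 nM; 10300 nM; 350 nM (3 entries)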